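A few compounds are considered here, and "the series" means these few. Any claim that something is new, unique, unknown or untested is made for them only; others in the source may bear on it.

In a functional assay on NCI-H661 cells (Homo sapiens) for cytotoxicity, read by WST assay, with a stated time of 72 h (on this read-out lower numbers stand for stronger inhibition and higher numbers for weaker inhibition), compound 2 `COc1cc2c(Nc3nc4ccc(C(=O)Nc5c(C)cccc5Cl)cc4s3)ncnc2cc1OCCCN1CCCC1` gives 45500 nM, the highest of the two numbers in hand. Compound 1 `COc1cc2c(Nc3nc4ccc(C(=O)Nc5c(C)cc(C)cc5C)cc4s3)ncnc2cc1OCCCN1CCCCC1C` gives 8800 nM in this assay, a lower number beyond the scatter. Compound 3 `COc1cc2c(Nc3nc4ccc(C(=O)Nc5c(C)cc(C)cc5C)cc4s3)ncnc2cc1OCCCN1CCCC1` carries 2,4,6-trimethylphenyl in place of 2-chloro-6-methylphenyl on an amide-type nitrogen. Among the measured compounds shown here, no measured pair isolates this change, so its size is not known from the data. Compound 1 shares the 2,4,6-trimethylphenyl and gives 8800 nM. On that basis a downward step a 3.8-fold lower number from compound 2 to compound 3 (0.58 log units; beyond the scatter) is expected. Compound 3 is estimated at 12000 nM, within 4000 nM to 40000 nM.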

Compound 3, half-maximal inhibitory concentration: 9600 nM
Beside the measured number, compound 3's estimate is 1.3-fold (0.10 log units) above it; measured number inside the range.
By their numbers in this assay, from the lowest: compounds 1 and 3 (each within the scatter of the next); then compound 2.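

In this assay, among the compounds shown here, 2,4,6-trimethylphenyl in place of 2-chloro-6-methylphenyl on the amide-type nitrogen gives a 4.7-fold lower number from compound 2 to compound 3 (0.68 log units; beyond the scatter), the first direct reading of this change, with the pyrrolidin-1-yl group held constant. Pyrrolidin-1-yl in place of 2-methylpiperidin-1-yl on the saturated chain carbon gives a 1.1-fold higher number from compound 1 to compound 3 (0.04 log units; within the scatter), so that swap does not separate these two compounds when 2,4,6-trimethylphenyl is present. Nothing at hand explains either result. Going by these compounds, whether the aryl step holds with 2-methylpiperidin-1-yl remains open. So does the effect of an unsubstituted phenyl on that nitrogen or a morpholin-4-yl group on the chain.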